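Swapping a Chloropyridyl Sulfonyl Group for Methoxyphenyl

This account rests on a few compounds, and the source may have more. Where it says the series, first, only, none or still open, it means among the compounds named here.

Of the compounds shown here, three built on a shared core have been tested in a functional assay on DLD-1 cells (Homo sapiens) for antiproliferative activity, read by CellTiter-Glo, with a stated time of 72 h; on this read-out higher numbers stand for weaker inhibition and lower numbers for stronger inhibition. Within the data shown here, compound 1 `CC1CCN(C2CCN(S(=O)(=O)c3cccnc3Cl)CC2)CC1` returns only a limit of the assay: in this assay compound 1 reads > 5000 nM, with no number behind it. the limit of > 5000 nM in this assay, at which 1 of the 3 values shown sits, describes where compound 1 stands; it is the one compound of the three at that limit. Compound 2 `CC1CCN(C2CCN(S(=O)(=O)c3ccc(C(C)C)cc3)CC2)CC1` gives 685 nM in this assay. Compound 3 `Cc1ccc(C#N)c(S(=O)(=O)N2CCC(N3CCC(C)CC3)CC2)c1` gives 285 nM in this assay. Because compound 1 sits at > 5000 nM as a limit, its distance to compound 2 or compound 3 cannot be stated as a number, only as at least the gap to the limit.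

Compound 4 `COc1cccc(S(=O)(=O)N2CCC(N3CCC(C)CC3)CC2)c1` awaits measurement. It differs from compound 1 in one place: 3-methoxyphenyl in place of 2-chloropyridin-3-yl on a sulfonyl sulfur. Among the measured compounds shown here, no step between two measured compounds isolates this change. Still, compound 2 and compound 3, which carry a six-membered aromatic ring of carbon only on the sulfonyl sulfur, both give numbers rather than limits, so a downward step from compound 1 is expected. The expected step from compound 1 to compound 4 is an at least 4.1-fold lower number from compound 1 to compound 4 (0.61 log units; beyond the scatter), beyond the scatter. Compound 4 is estimated at 1200 nM, most likely between 300 nM and 5000 nM.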

Compound 4, half-maximal inhibitory concentration: > 5000 nM
Compound 4 ended at the assay's limit (the forecaster's own chance of this, stated with the estimate: 20%); middle value at least 4.1-fold (0.61 log units) from the limit.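

Among these compounds, compound 4, like compound 1, returns only a limit of the assay, so no step between the two can be read. Both now stand at that limit: the limit of > 5000 nM in this assay, at which 2 of the 4 values shown sit.

The compounds shown leave open whether 3-methoxyphenyl in place of 2-chloropyridin-3-yl on a sulfonyl sulfur changes the antiproliferative read-out at all, and by how much.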